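The source may report more compounds than this note shows. Statements on the series, on what has been measured and on what is new or still open speak of the compounds shown alone.

Of the compounds shown here, three sharing one core have been measured in an assay for binding affinity to dual specificity mitogen-activated protein kinase kinase 4 (Homo sapiens), read by KINOMEscan, tested at 100 nM; a higher number here means a weaker effect of the compound at the concentration tested, a lower number a stronger effect. Compound 1, `CCCS(=O)(=O)Nc1ccc(F)c(C(=O)c2n[nH]c3ncc(-c4ccccc4)cc23)c1F`, gives 2.4%. Compound 2, `CCCS(=O)(=O)Nc1ccc(F)c(C(=O)c2n[nH]c3ncc(-c4ccccc4Cl)cc23)c1F`, gives 9.3%, and compound 3, `CCCS(=O)(=O)Nc1ccc(F)c(C(=O)c2n[nH]c3ncc(-c4cccc(F)c4)cc23)c1F`, gives 8.2%. Among these three numbers compound 3 stands second highest, with compound 2 nearest a number 1.1 percentage points lower from compound 2 to compound 3 (within the scatter) and compound 1 furthest a number 5.8 percentage points higher from compound 1 to compound 3 (within the scatter), so all three read-outs sit close together.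

The next compound, compound 4, is `CCCS(=O)(=O)Nc1ccc(F)c(C(=O)c2n[nH]c3ncc(-c4ccc(F)cc4)cc23)c1F`. The change from compound 3 is a rearrangement of the same atoms: 4-fluorophenyl in place of 3-fluorophenyl on an aromatic carbon

Among the compounds with values here, two measured steps touch on this change. The step of a number 5.8 percentage points higher from compound 1 to compound 3 (within the scatter) shows what adding a fluoro in place of hydrogen on that ring did, and the step of a number 1.1 percentage points lower from compound 2 to compound 3 (within the scatter) shows what swapping one substituted phenyl for another did. Both stayed within the scatter, and the step of a number 6.9 percentage points higher from compound 1 to compound 2 (within the scatter) did too. Within the data shown here, no measured step moves a fluoro from one position of the phenyl to another, so the direction of any shift is unknown; given the small steps seen so far, no step beyond the scatter is expected in this assay .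

The expected read-out for compound 4 is therefore 6%, within 1% to 16%, a step of a number 2.2 percentage points lower from compound 3 to compound 4 (within the scatter).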

Compound 4, a percentage reported as activity, at one concentration (the size of the read-out at that concentration, not a potency): 2.1%
Compound 4: middle estimate off by 3.9 percentage points, on the high side; low and high end bracket the measured number.
By their numbers in this assay, from the lowest: compounds 4, 1, 3 and 2 (each within the scatter of the next).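

Within the data shown here, this is the first measured step that moves a fluoro around the phenyl ring while keeping the same atoms: in this assay, 4-fluorophenyl in place of 3-fluorophenyl gives a number 6.1 percentage points lower from compound 3 to compound 4 (within the scatter) and so does not separate the two compounds. At the same place on the shared core, 4-fluorophenyl in place of 2-chlorophenyl gives a number 7.2 percentage points lower from compound 2 to compound 4 (within the scatter) and fluoro in place of hydrogen gives a number 0.3 percentage points lower from compound 1 to compound 4 (within the scatter), which leaves all four compounds within the scatter of one another. Nothing available here explains why these read-outs stay so close together.

The compounds shown leave open whether any group at this place can shift the read-out beyond the scatter, for instance an amine, a carboxylic acid or a longer chain on the phenyl ring. Each read-out comes from a single concentration, so they also leave open whether these four compounds would show a stronger or weaker effect at any other concentration.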